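A few compounds are considered here, and "the series" means these few. Any claim that something is new, unique, unknown or untested is made for them only; others in the source may bear on it.

Measured so far:
compound 1 `O=C(CCC(=O)OCCCCCCSc1ccc([N+](=O)[O-])c2nonc12)Nc1ccccc1F`, 2350 nM in a functional assay on HOS cells (Homo sapiens) for inhibition, read by MTT assay, with a stated time of 72 h; a lower number here means a stronger inhibitor, a higher number a weaker inhibitor
compound 2 `Cc1ccccc1NC(=O)CCC(=O)OCCCCCCSc1ccc([N+](=O)[O-])c2nonc12`, 4020 nM in this assay

Compound 1 stands at the smaller of these two numbers, yet the step of a 1.7-fold higher number from compound 1 to compound 2 (0.23 log units; within the scatter) lies within the scatter, so the two are not truly separated. Compound 3 `Cc1ccc(NC(=O)CCC(=O)OCCCCCCSc2ccc([N+](=O)[O-])c3nonc23)cc1` has not been measured. It differs from compound 1 by 4-methylphenyl in place of 2-fluorophenyl on an amide-type nitrogen. Among the measured compounds shown here, the one measured step, a 1.7-fold higher number from compound 1 to compound 2 (0.23 log units; within the scatter), also swapped fluoro for methyl and stayed within the scatter, so no step beyond the scatter is expected in this assay. Compound 3 is expected to give about 3000 nM, with a range from 1200 nM to 8000 nM. For compound 3 the expected step is a 1.3-fold higher number from compound 1 to compound 3 (0.11 log units; within the scatter).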

Compound 3, half-maximal inhibitory concentration: 3340 nM
Compound 3: middle estimate off by 1.1-fold (0.05 log units), on the low side, and the stated range covers the measured number.
By their numbers in this assay, from the lowest: compounds 1, 3 and 2 (each within the scatter of the next).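

On the amide-type nitrogen, 4-methylphenyl in place of 2-fluorophenyl stays within the scatter in this assay (a 1.4-fold higher number from compound 1 to compound 3 (0.15 log units; within the scatter)), and so does 4-methylphenyl in place of 2-methylphenyl (a 1.2-fold lower number from compound 2 to compound 3 (0.08 log units; within the scatter)). This position has now carried three substituted phenyl groups with no separation among them, and changing where the methyl sits on the ring shows no readable effect. No measurement at hand offers a reason for this.

All three compounds carry a phenyl ring here with one small group on it. From the compounds shown here alone, it remains open whether a ring bearing an amine or a carboxylic acid, or a longer chain in place of the ring, would shift the number beyond the scatter.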